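A few compounds are considered here, and "the series" means these few. Any claim that something is new, unique, unknown or untested is made for them only; others in the source may bear on it.

Three amides on a shared core have been measured in an assay on LtK cells with ATP-sensitive inward rectifier potassium channel 11 (Homo sapiens) as the target; on this read-out lower numbers stand for an effect already at smaller amounts and higher numbers for an effect only at larger amounts of compound. Compound 1 `CCCC(C)C(=O)Nc1c(C(O)(C(F)(F)F)C(F)(F)F)ccc2ccccc12` carries a 1-methylbutyl group on the carbonyl carbon, and in this assay compound 1 shows only > 10000 nM, a limit of the assay rather than a number (the limit of > 10000 nM in this assay, at which 1 of the 3 values shown sits). Compound 2 `CC(C)CCC(=O)Nc1c(C(O)(C(F)(F)F)C(F)(F)F)ccc2ccccc12`, with isopentyl in that place, gives 49 nM in this assay, a move of an at least 200-fold lower number from compound 1 to compound 2 (2.30 log units; beyond the scatter). Compound 3 `O=C(Nc1c(C(O)(C(F)(F)F)C(F)(F)F)ccc2ccccc12)c1ccccc1Cl`, bearing 2-chlorophenyl, gives 2040 nM in this assay. Compound 4 `O=C(Nc1c(C(O)(C(F)(F)F)C(F)(F)F)ccc2ccccc12)c1cccc([N+](=O)[O-])c1` is not yet measured; it differs from compound 1 thus: 3-nitrophenyl in place of 1-methylbutyl on a carbonyl carbon. The closest measured change is the aryl exchange giving an at least 4.9-fold lower number from compound 1 to compound 3 (0.69 log units; beyond the scatter), so a lower number is expected for compound 4, a step of an at least 4.0-fold lower number from compound 1 to compound 4 (0.60 log units; beyond the scatter). The estimate for compound 4 is 2500 nM, between 600 nM and 10000 nM.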

Compound 4, half-maximal effective concentration: 117 nM
Compound 4: the middle estimate sits 21-fold (1.33 log units) above what was measured; measured number below the stated range.
By their numbers in this assay, from the lowest: compound 2; then compound 4; then compound 3. At a limit, above all of these: compound 1.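

An aromatic group on the carbonyl carbon need not lose much against isopentyl: 3-nitrophenyl gives a 2.4-fold higher number from compound 2 to compound 4 (0.38 log units; beyond the scatter). The choice of aromatic group matters, since exchanging 2-chlorophenyl for 3-nitrophenyl gives a 17-fold lower number from compound 3 to compound 4 (1.24 log units; beyond the scatter). Against 1-methylbutyl, the exchange gives an at least 85-fold lower number from compound 1 to compound 4 (1.93 log units; beyond the scatter), a step read from a limit: the limit of > 10000 nM in this assay, at which 1 of the 4 values shown sits.

As far as these compounds go, it remains open whether the gap between the two aromatic groups follows the nitro group itself or its place on the phenyl ring. Also open, from the compounds shown here alone, is how a plain phenyl or a pyridine ring on the carbonyl carbon would read.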